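Cyclohexyl in Place of Quinolinyl on Two Sulfonamide Cores

The source may report more compounds than this note shows. Statements on the series, on what has been measured and on what is new or still open speak of the compounds shown alone.

Compound 1 `C=C(CC)C(=O)c1ccc(OCC(=O)NCCNS(=O)(=O)c2cccc3cccnc23)c(Cl)c1Cl` and compound 2 `C=C(CC)C(=O)c1ccc(OCC(=O)NCCNS(=O)(=O)C2CCCCC2)c(Cl)c1Cl` share a core and differ only at the sulfonyl group. In a functional assay on HL-60 cells (Homo sapiens) for cytotoxicity, read by luminescence (on this read-out higher numbers stand for weaker inhibition and lower numbers for stronger inhibition), compound 1 gives 1330 nM, and compound 2 gives 1340 nM; the change cyclohexyl in place of quinolin-8-yl on a sulfonyl sulfur made a step of a 1.0-fold higher number from compound 1 to compound 2 (0.00 log units; within the scatter). Compound 3 `C=C(CC)C(=O)c1ccc(OCC(=O)NC2CCN(S(=O)(=O)c3cccc4cccnc34)CC2)c(Cl)c1Cl` has a different core; how its core differs from the core of compound 1 is not broken down here. In this assay compound 3 gives 970 nM, which lies within the scatter of the two others. Compound 4 `C=C(CC)C(=O)c1ccc(OCC(=O)NC2CCN(S(=O)(=O)C3CCCCC3)CC2)c(Cl)c1Cl` is not yet measured. It carries the same kind of change, (cyclohexyl in place of quinolin-8-yl on a sulfonyl sulfur), though here the sulfonyl sulfur's other neighbour is a sulfonamide nitrogen in a ring, whereas in the earlier pair it is a sulfonamide nitrogen. Compound 4 is expected to show a step of a 1.0-fold higher number from compound 3 to compound 4 (0.01 log units; within the scatter), because the earlier step of a 1.0-fold higher number from compound 1 to compound 2 (0.00 log units; within the scatter) stayed within the scatter. The estimate for compound 4 is 1000 nM, with a range from 500 nM to 2000 nM.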

Compound 4, half-maximal inhibitory concentration: 2940 nM
Estimate against measurement, compound 4: 2.9-fold (0.47 log units) below; the measured number lies above the stated range.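

Cyclohexyl in place of quinolin-8-yl on a sulfonyl sulfur gave a step of a 3.0-fold higher number from compound 3 to compound 4 (0.48 log units; beyond the scatter) in this assay. The same change did not give the same step on the two cores: the same change on two cores in this assay, a 1.0-fold higher number (0.00 log units; within the scatter) from compound 1 to compound 2 and a 3.0-fold higher number (0.48 log units; beyond the scatter) from compound 3 to compound 4, 3.0-fold (0.48 log units) apart, beyond the scatter of two such steps
This shows that the size of the step depends on the core for these two pairs, but with one pair on each core it does not show which part of the core matters or what the step would be on any further core.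

The compounds shown leave open whether a phenyl or a methyl group on the sulfonyl sulfur would give steps that also differ from one core to the other. They also leave open what a longer chain in place of the ethylene chain of compound 1 would do to the step.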